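This account rests on a few compounds, and the source may have more. Where it says the series, first, only, none or still open, it means among the compounds named here.

Compound 2, with the structure `FC(F)(F)c1ccc(Nc2cc3[nH]c(C4CC4)nc3cn2)nc1`, belongs to a pair of compounds measured in a physicochemical assay for solubility, using the shake flask method, measured as kinetic solubility, with a stated time of 20 h, at pH 2; on this read-out higher numbers stand for higher solubility and lower numbers for lower solubility. In this assay compound 2 gives 198000 nM. The other compound is compound 1, with the structure `FC1(F)CCC(c2nc3cnc(Nc4ccc(C(F)(F)F)cn4)cc3[nH]2)C1`, which in this assay gives 185000 nM. Compound 2 has the higher of the two numbers, but the step of a 1.1-fold higher number from compound 1 to compound 2 (0.03 log units; within the scatter) is within the scatter, so the two compounds cannot be told apart on this read-out. The unmeasured compound 3 has the structure `FC1(F)CC(c2nc3cnc(Nc4ccc(C(F)(F)F)cn4)cc3[nH]2)C1`. It differs from compound 2 as follows: 3,3-difluorocyclobutyl in place of cyclopropyl on an aromatic carbon. Among the measured compounds shown here, the only measured step that bears on this change is the one from compound 1 to compound 2, which swapped 3,3-difluorocyclopentyl for cyclopropyl and was within the scatter. The change to compound 3 runs the other way, and the expected step of a 1.1-fold lower number from compound 2 to compound 3 (0.03 log units; within the scatter) is therefore no step beyond the scatter. Compound 3 is estimated at 185000 nM, with a range from 100000 nM to 350000 nM.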

Compound 3, solubility: 181000 nM
The estimate for compound 3 lay 1.0-fold (0.01 log units) above the measured number; measured number inside the range.
By their numbers in this assay, from the lowest: compounds 3, 1 and 2 (each within the scatter of the next).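

In this assay, the aromatic carbon between two ring nitrogen atoms has now carried three different carbon rings, and the numbers still cannot be told apart. Replacing cyclopropyl with 3,3-difluorocyclobutyl gives a 1.1-fold lower number from compound 2 to compound 3 (0.04 log units; within the scatter), while replacing 3,3-difluorocyclopentyl with the same group gives a 1.0-fold lower number from compound 1 to compound 3 (0.01 log units; within the scatter). The earlier pair offered only one comparison, whereas these steps show that, among these three compounds, the 3,3-difluorocyclobutyl group also leaves the read-out within the scatter, even though it brings in 6 heavy atoms where cyclopropyl has 3.

Still open, as far as these compounds go, is whether a group of a different kind at this position, such as an amine or a carboxylic acid, would give a number beyond the scatter. Nothing shown here explains why these three numbers lie so close together.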